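Fluoro for methyl on the open-chain compound 3

The source may report more compounds than this note shows. Statements on the series, on what has been measured and on what is new or still open speak of the compounds shown alone.

Measured in a functional assay on SK-MEL-28 cells (Homo sapiens) for inhibition, read by colorimetric assay and MTT assay, with a stated time of 72 h; on this read-out lower numbers stand for stronger inhibition and higher numbers for weaker inhibition:
compound 1 `COc1ccc2c(c1)-c1cnc(n1C)OCCCCCCCCO2` gives 57000 nM
compound 2 `Cn1c2cnc1OCCCCCCCCOc1cc(F)ccc1-2` gives 58000 nM
compound 3 `C=CCCCCOc1ccc(C)cc1-c1cnc(OCCC=C)n1C` gives 83000 nM

In this assay compound 3 gives 83000 nM, which lies within the scatter of both other values. The three compounds therefore form one group, with no order among them.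

Compound 4 `C=CCCCCOc1ccc(F)cc1-c1cnc(OCCC=C)n1C` is the next case. It carries fluoro in place of methyl on an aromatic carbon, para to a (hex-5-en-1-yl)oxy group and meta to a large group (fluoro in place of methyl on an aromatic carbon). Going by the values given here, no measured pair isolates this change, so the size of the step can only be judged loosely.

The nearest guide is compound 2, which also bears fluoro and gives 58000 nM. That value sits within the scatter of compound 1 at 57000 nM, and neither value departs beyond the scatter from compound 3. On that basis, no step beyond the scatter is expected in this assay, in either direction.

The expected change, a 1.1-fold lower number from compound 3 to compound 4 (0.04 log units; within the scatter), is an estimate and stays within the scatter. For compound 4 the estimated value is 75000 nM, with an expected range of 40000 nM to 130000 nM.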

Compound 4, half-maximal inhibitory concentration: 82000 nM
The estimate for compound 4 lay 1.1-fold (0.04 log units) below the measured number, and the stated range covers the measured number.
By their numbers in this assay, from the lowest: compounds 1, 2, 4 and 3 (each within the scatter of the next).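

In this assay, going by these compounds alone, the open-chain pair gives the first comparison that differs in one place only, and the exchange of methyl for fluoro gives a 1.0-fold lower number from compound 3 to compound 4 (0.01 log units; within the scatter) as its step. At this aromatic carbon, para to a (hex-5-en-1-yl)oxy group and meta to a large group, the two groups therefore cannot be told apart by this read-out, and the fluoro compound 4 stays in one group with compounds 1, 2 and 3, with no order among them. No measurement at hand offers an explanation for this result.

The compounds shown leave open whether a group of another kind at this carbon, such as an amine or a carboxylic acid, or a longer chain in place of the (hex-5-en-1-yl)oxy group, would give a step beyond the scatter. Within the data shown here, compounds 1 and 2 differ from the open-chain pair in more than one place, so the series still holds no single-place step that relates them to compounds 3 and 4.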